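A Five-Membered Aromatic Ring in Place of the Sultam

The source may hold more compounds than are shown below. What is called first, only, known or untested is meant among the compounds shown, and "the series" means these compounds.

Compound 1 `CC(C)C(c1ccc(-c2ccc3cccc(F)c3c2)[nH]c1=O)N1CCCCS1(=O)=O` gives 0.0733 h in an ADME assay on microsomes from liver (Mus musculus) for metabolic stability (a higher number here means that the compound lasts longer, a lower number that the compound disappears faster), the lowest of the three numbers recorded here. Compound 2 `CC(C)C(c1ccc(-c2ccc3cccc(F)c3c2)[nH]c1=O)N1CCCCC1=O` gives 0.0967 h in this assay, and the step of a 1.3-fold higher number from compound 1 to compound 2 (0.12 log units; within the scatter) stays within the scatter. Compound 3 `CC(C)C(Cc1nnn[nH]1)c1ccc(-c2ccc3cccc(F)c3c2)[nH]c1=O` gives 0.853 h in this assay; the step of a 12-fold higher number from compound 1 to compound 3 (1.07 log units; beyond the scatter) is the largest among the measured pairs, and the step of an 8.8-fold higher number from compound 2 to compound 3 (0.95 log units; beyond the scatter) points the same way.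

Compound 4 `CC(C)C(c1noc(=O)[nH]1)c1ccc(-c2ccc3cccc(F)c3c2)[nH]c1=O` differs from compound 1 at the same position: a group of 6 heavy atoms (2 carbon, 2 nitrogen, 2 oxygen; one five-membered aromatic ring with 3 hetero atoms) in place of a group of 8 heavy atoms (4 carbon, 1 nitrogen, 2 oxygen, 1 sulfur; one six-membered non-aromatic ring with 2 hetero atoms), on a saturated chain carbon bound to an aromatic carbon and a saturated chain carbon. The step of a 12-fold higher number from compound 1 to compound 3 (1.07 log units; beyond the scatter) is the closest comparison, for it also put a five-membered aromatic ring with a hydrogen-bond donor in place of the same six-membered non-aromatic ring with 2 hetero atoms. The step of a 1.3-fold higher number from compound 1 to compound 2 (0.12 log units; within the scatter) shows that exchanging that ring for another six-membered non-aromatic ring left the number essentially unchanged. Going by the values given here, compound 4 is therefore expected to show a step of a 6.8-fold higher number from compound 1 to compound 4 (0.83 log units; beyond the scatter), a clear gain beyond the scatter, though only one comparable example supports its size. For compound 4 the estimate in this assay is 0.5 h, with a range from 0.15 h to 1.5 h.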

Compound 4, half-life: > 3 h
Compound 4 ended at the assay's limit; the forecaster's own chance of this, stated with the estimate: 5%; middle value at least 6.0-fold (0.77 log units) from the limit.
By their numbers in this assay, from the lowest: compounds 1 and 2 (each within the scatter of the next); then compound 3. At a limit, above all of these: compound 4.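

The value of compound 4 in this assay is a limit of the assay and not a number: the limit of > 3 h in this assay, at which 1 of the 4 values shown sits. Going by these compounds alone, the earlier compounds held only one five-membered aromatic ring at this position, on a saturated chain carbon bound to an aromatic carbon and a saturated chain carbon, whereas an at least 3.5-fold higher number from compound 3 to compound 4 (0.54 log units; beyond the scatter) now shows that two such groups of equal heavy-atom count are not interchangeable here, since the step lies beyond the scatter. From the compounds shown here alone, the steps of an at least 40-fold higher number from compound 1 to compound 4 (1.61 log units; beyond the scatter) and an at least 31-fold higher number from compound 2 to compound 4 (1.49 log units; beyond the scatter) show that the change from either six-membered non-aromatic ring carries the number to the top of the measurable range, so the true size of both steps stays unknown.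

The compounds shown do not separate the identity of the ring from the way it is attached, as compound 3 carries its ring on a methyl link and compound 4 carries its ring directly on the saturated chain carbon. They also leave open whether the ring of compound 4 on a methyl link, or a carboxylic acid or an amine at this place, would hold the same gain.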